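Aryl substituent swap on the pyrazinyl triazolethiol hydrazone series

The source may report more compounds than this note shows. Statements on the series, on what has been measured and on what is new or still open speak of the compounds shown alone.

Measured so far in a functional assay, with a stated time of 30 min; a lower number here means a stronger inhibitor, a higher number a weaker inhibitor:
compound 1 `Oc1ccc2ccccc2c1/C=N/n1c(S)nnc1-c1cnccn1`, 69200 nM
compound 2 `Oc1ccc(/C=N/n2c(S)nnc2-c2cnccn2)cc1`, 58900 nM
compound 3 `N#Cc1ccc(/C=N/n2c(S)nnc2-c2cnccn2)cc1`, 47800 nM

In this assay compound 2 holds the second highest of the three numbers; its neighbours on either side, compound 1 and compound 3, both sit within the scatter of it, so no ordering among the three is supported.

Compound 4 `Sc1nnc(-c2cnccn2)n1/N=C/c1ccc(Cl)cc1` is not yet measured. It differs from compound 2 by chloro in place of hydroxy on an aromatic carbon. Among the measured compounds shown here, the one measured step at the same place, a 1.2-fold lower number from compound 2 to compound 3 (0.09 log units; within the scatter), stayed within the scatter; only this single step bears on the new change. The step of a 1.2-fold lower number from compound 2 to compound 4 (0.07 log units; within the scatter) is therefore expected to be no larger than the scatter. For compound 4 the estimate in this assay is 50000 nM, with a range from 20000 nM to 125000 nM.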

Compound 4, half-maximal inhibitory concentration: 39800 nM
Beside the measured number, compound 4's estimate is 1.3-fold (0.10 log units) above it, and the stated range covers the measured number.
By their numbers in this assay, from the lowest: compounds 4, 3, 2 and 1 (each within the scatter of the next).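

Working from this assay, the change from 4-hydroxyphenyl to 4-chlorophenyl gives a 1.5-fold lower number from compound 2 to compound 4 (0.17 log units; within the scatter), although the entering chloro counts no hydrogen-bond donor or acceptor and the leaving hydroxy counts one of each. Exchanging the nitrile for chloro at the same place gives a 1.2-fold lower number from compound 3 to compound 4 (0.08 log units; within the scatter), so hydroxy, cyano and chloro at this place now form a set with no step beyond the scatter. No supporting measurement bears on this flat result.

On these data alone, whether an amine, a carboxylic acid or a longer chain at this place would give a step beyond the scatter remains open. So does whether the same exchanges would read alike at another place on the aromatic ring.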